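A methanesulfonamido swap on compound 3

The source may hold more compounds than are shown below. What is called first, only, known or untested is meant among the compounds shown, and "the series" means these compounds.

Measured in a physicochemical assay for solubility, measured as thermodynamic solubility, at pH 6.5; a higher number here means a more soluble compound, a lower number a less soluble compound:
Compound 1 `O=C(Nc1ccc(Cl)c(-c2ccccn2)c1)c1ccc(-n2cncn2)nc1`: 8 ug/mL
Compound 2 `Cc1ncn(-c2ccc(C(=O)Nc3ccc(Cl)c(-c4ccccn4)c3)c(C)n2)n1`: 6 ug/mL
Compound 3 `CS(=O)(=O)Cc1ccc(C(=O)Nc2ccc(Cl)c(-c3ccccn3)c2)c(Cl)c1`: 3 ug/mL

In this assay compound 3 gives 3 ug/mL. Compound 2 gives 6 ug/mL, a value that sits within the scatter of compound 3. Compound 1 gives 8 ug/mL, a gap to compound 3 that exceeds the scatter. Compound 4 `CS(=O)(=O)Nc1ccc(C(=O)Nc2ccc(Cl)c(-c3ccccn3)c2)c(Cl)c1` carries methanesulfonamido in place of (methylsulfonyl)methyl on an aromatic carbon, meta to a chloro group and para to a large group (methanesulfonamido in place of (methylsulfonyl)methyl on an aromatic carbon). Within the data shown here, no measured pair shows this change, so the expectation rests on compound 3 at 3 ug/mL. In this assay no step beyond the scatter is expected, the estimated step being a 1.3-fold higher number from compound 3 to compound 4 (0.12 log units; within the scatter). For compound 4 the estimate is 4 ug/mL, with an expected range of 1.5 ug/mL to 12 ug/mL.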

Compound 4, solubility: 1 ug/mL
Compound 4: middle estimate off by 4.0-fold (0.60 log units), on the high side, and the stated range ends above it.
By their numbers in this assay, from the lowest: compound 4; then compounds 3, 2 and 1 (each within the scatter of the next, the first and the last beyond it).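

Methanesulfonamido in place of (methylsulfonyl)methyl, on an aromatic carbon meta to a chloro group and para to a large group, gives the first single-place comparison here: in this assay the change brings a 3.0-fold lower number from compound 3 to compound 4 (0.48 log units; beyond the scatter). The two groups have the same count of heavy atoms, yet they differ by a nitrogen for a carbon and by one hydrogen-bond donor, and that exchange alone moves the number beyond the scatter. Nothing measured here accounts for the step.

From the compounds shown here alone, how an amine, a carboxylic acid or a longer chain would read at this position remains open. So does whether the same swap gives a like step in a compound without the chloro group.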